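The source may report more compounds than this note shows. Statements on the series, on what has been measured and on what is new or still open speak of the compounds shown alone.

Measured compounds in a functional assay on HT-29 cells (Homo sapiens) for cytotoxicity, read by MTT assay, with a stated time of 72 h; on this read-out lower numbers stand for stronger inhibition and higher numbers for weaker inhibition:
Compound 1 `COc1cc2c(Oc3ccc(NC(=O)N/N=C/c4ccc([N+](=O)[O-])cc4)cc3F)ccnc2cc1OCCCN1CCCC1` gives 310 nM.
Compound 2 `COc1cc2c(Oc3ccc(NC(=O)N/N=C/c4ccc(C(F)(F)F)cc4)cc3F)ccnc2cc1OCCCN1CCCC1` gives 810 nM.
Compound 3 `COc1ccc(/C=N/NC(=O)Nc2ccc(Oc3ccnc4cc(OCCCN5CCCCC5)c(OC)cc34)c(F)c2)cc1` gives 590 nM.

Compound 2 has the highest number of the three in this assay; compound 3 sits within the scatter of it, while compound 1 is further away, and the change from nitro to trifluoromethyl reads as a 2.6-fold higher number from compound 1 to compound 2 (0.42 log units; beyond the scatter). Compound 4 `COc1cc2c(Oc3ccc(NC(=O)N/N=C/c4ccc(C(F)(F)F)cc4)cc3F)ccnc2cc1OCCCN1CCCCC1` differs from compound 2 by piperidin-1-yl in place of pyrrolidin-1-yl on a saturated chain carbon, three bonds along the chain from an oxygen on an aromatic ring. Among the measured compounds shown here, no measured pair isolates this change: compound 3 carries the same piperidine but a different aromatic group, and the only measured step concerns another part of the molecule. With the compound 2 and compound 3 numbers lying within the scatter of each other, the expected step of a 1.0-fold lower number from compound 2 to compound 4 (0.01 log units; within the scatter) is none beyond the scatter. Compound 4 is therefore estimated at 800 nM, with a range from 300 nM to 2200 nM.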

Compound 4, half-maximal inhibitory concentration: 660 nM
Compound 4: the middle estimate sits 1.2-fold (0.08 log units) above what was measured, within the range that was stated.
By their numbers in this assay, from the lowest: compounds 1, 3, 4 and 2 (each within the scatter of the next, the first and the last beyond it).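

In this assay, the step from pyrrolidin-1-yl to piperidin-1-yl, now seen on its own, is a 1.2-fold lower number from compound 2 to compound 4 (0.09 log units; within the scatter) and so makes no clear difference at this place on the chain. With piperidin-1-yl held fixed, trifluoromethyl in place of methoxy is a 1.1-fold higher number from compound 3 to compound 4 (0.05 log units; within the scatter) and also stays inside the scatter. No measurement here explains why these swaps change so little. Still open, as far as these compounds go, is whether morpholine or dimethylamino at the end of this chain would also leave the number unchanged, and whether a 2-(piperidin-1-yl)ethyl chain would do the same.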